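The compounds below may be only part of what the source reports. "The series", "measured", "known", "first", "only" and "open" are said of these compounds alone.

Measured so far in an ADME assay for permeability, using PAMPA, with a stated time of 3 h; a higher number here means that the compound crosses the layer faster, a lower number that the compound crosses the layer more slowly:
Compound 1 `O=C(Nc1ccc(C(F)(F)F)cc1)c1cc(Cl)ccc1O`, which in this assay gives 6.9 10^-6 cm/s.
Compound 2 `O=C(Nc1cccc(C(F)(F)F)c1)c1cc(Cl)ccc1O`, which in this assay gives 4.2 10^-6 cm/s.
Compound 3 `O=C(Nc1cccc(O)c1)c1cc(Cl)ccc1O`, which in this assay gives 15.9 10^-6 cm/s.

Compound 1 and compound 2 contain the same atoms joined differently; the difference between the two cores is not broken down here, and their values lie within the scatter of each other. Compound 3 arises from compound 2 by hydroxy in place of trifluoromethyl on an aromatic carbon, a change that gave a 3.8-fold higher number from compound 2 to compound 3 (0.58 log units; beyond the scatter). Compound 4 `O=C(Nc1ccc(O)cc1)c1cc(Cl)ccc1O` is not yet measured; it arises from compound 1 by hydroxy in place of trifluoromethyl on an aromatic carbon. The surroundings differ: in compound 3 the hydroxy sits meta to a large group, in compound 4 para to a large group, so this is the same kind of change, not the same change. A step of about a 2.9-fold higher number from compound 1 to compound 4 (0.46 log units; beyond the scatter) is expected, resting on a 3.8-fold higher number from compound 2 to compound 3 (0.58 log units; beyond the scatter). Compound 4 is thus estimated at 20 10^-6 cm/s, between 10 10^-6 cm/s and 40 10^-6 cm/s.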

Compound 4, apparent permeability: 33.1 10^-6 cm/s
Beside the measured number, compound 4's estimate is 1.7-fold (0.22 log units) below it; low and high end bracket the measured number.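

Replacing trifluoromethyl with hydroxy again raised the number in this assay, giving a 4.8-fold higher number from compound 1 to compound 4 (0.68 log units; beyond the scatter). Set beside the earlier case, the change carried over between the two cores with a step of similar size: the same change on two cores in this assay, a 3.8-fold higher number (0.58 log units; beyond the scatter) from compound 2 to compound 3 and a 4.8-fold higher number (0.68 log units; beyond the scatter) from compound 1 to compound 4, 1.3-fold (0.10 log units) apart, within the scatter of two such steps. Among the compounds shown here, this rests on only two pairs, whose cores differ only in where the group sits, so it does not show that the step would hold on a more distant core, and it does not explain why the number rises.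

The compounds shown leave open how another group in the same place, such as an amine or a carboxylic acid, would compare with hydroxy. They also leave open whether a smaller replacement, such as a methyl group, would move the number at all.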